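Swapping an aryl urea for a piperidine amide

A few compounds are considered here, and "the series" means these few. Any claim that something is new, unique, unknown or untested is made for them only; others in the source may bear on it.

Among the compounds with values here, compound 1 `Cn1cncc1CN1CC(N(CC2CCN(C(=O)Nc3ccc(Br)cc3)CC2)S(=O)(=O)c2ccccn2)Cc2cc(C#N)ccc21` has the higher of the two numbers so far: in an ADME assay on Caco-2 cells (Homo sapiens) for permeability, in the apical to basolateral direction (on this read-out higher numbers stand for higher permeability and lower numbers for lower permeability), compound 1 gives 0.6 10^-6 cm/s, while compound 2 `Cn1cncc1CN1CC(N(Cc2ccc(S(C)(=O)=O)cc2)S(=O)(=O)c2ccccn2)Cc2cc(C#N)ccc21` gives 0.2 10^-6 cm/s, a gap beyond the usual scatter. Compound 3 `Cn1cncc1CN1CC(N(CC2CCN(C(=O)N3CCCCC3)CC2)S(=O)(=O)c2ccccn2)Cc2cc(C#N)ccc21` keeps the core of compound 1 and changes one place: piperidin-1-yl in place of (4-bromophenyl)amino on a carbonyl carbon. Within the data shown here, with no measured step of this kind to lean on, the expected change a 1.7-fold higher number from compound 1 to compound 3 (0.22 log units; within the scatter) is a modest rise, close to the edge of the scatter. Compound 3 is therefore estimated at 1 10^-6 cm/s, with a range from 0.3 10^-6 cm/s to 3 10^-6 cm/s.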

Compound 3, apparent permeability: 0.6 10^-6 cm/s
Beside the measured number, compound 3's estimate is 1.7-fold (0.22 log units) above it, within the range that was stated.
By their numbers in this assay, from the lowest: compound 2; then compounds 1 and 3 (each within the scatter of the next).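

The step of no change at the digits printed from compound 1 to compound 3 (within the scatter) in this assay shows that this place on a carbonyl carbon does not depend on an aromatic ring, a bromine or a hydrogen-bond donor in the group it carries. With piperidin-1-yl in place of (4-bromophenyl)amino, all three are gone and the read-out stays within the scatter. No measurement at hand bears on what lies behind this result. Still open, going by these compounds, is whether morpholin-4-yl or dimethylamino on the same carbonyl carbon would also leave the number within the scatter.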